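The source may hold more compounds than are shown below. What is called first, only, known or untested is meant among the compounds shown, and "the series" means these compounds.

Measured compounds in a functional assay on cells (T-cell, Homo sapiens) for inhibition; on this read-out lower numbers stand for stronger inhibition and higher numbers for weaker inhibition:
- compound 1 `COc1ccc(-c2cnc3nc(N)nc(N4CCN(C(=O)c5ccccc5)CC4)c3n2)cc1OC`: 400 nM
- compound 2 `COc1ccc(-c2cnc3nc(N)nc(NC(C)C)c3n2)cc1OC`: 600 nM
- compound 3 `CCOc1nc(N)nc2ncc(-c3ccc(C#N)cc3)nc12`: a limit, > 10000 nM

Compound 1 and compound 2 share the same core with different groups attached, and the two numbers from this assay lie within the usual scatter of repeated measurements of each other, so neither can be set apart from the other. Compound 3 carries a different substituent pattern on the core and gives only a limit in this assay, not a number. Compound 4 `COc1ccc(-c2cnc3nc(N)nc(N4CCN(C(=O)COc5ccc(Cl)cc5)CC4)c3n2)cc1OC` is not yet measured. It differs from compound 1 in one place: (4-chlorophenoxy)methyl in place of phenyl on a carbonyl carbon. Among the compounds with values here, no measured pair in this set shows a change of this kind, so there is nothing to say how large a step to expect from it. The step from compound 1 to compound 4 is expected to be small, no change at the digits printed from compound 1 to compound 4 (within the scatter), without a clear direction beyond the scatter. Compound 4 is therefore estimated at 400 nM, between 130 nM and 1300 nM.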

Compound 4, half-maximal inhibitory concentration: 0.5 nM
Compound 4: the middle estimate sits 800-fold (2.90 log units) above what was measured; the whole stated range lies above it.
By their numbers in this assay, from the lowest: compound 4; then compounds 1 and 2 (each within the scatter of the next). At a limit, above all of these: compound 3.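

In this assay, the group on the carbonyl carbon proves able to move the read-out a long way: (4-chlorophenoxy)methyl in place of phenyl gives an 800-fold lower number from compound 1 to compound 4 (2.90 log units; beyond the scatter) on a single change. The values of compound 1 and compound 2 lie within the scatter of each other, so they gave no sign that a single change on this scaffold could have an effect of this size. No measurement shown here explains why this change has so large an effect.

As far as these compounds go, the entering group differs from phenyl in three ways at once, through its added methylene carbon, its oxygen and its chlorine, so which of these matters remains open. Whether plain phenoxymethyl, a fluorine in place of the chlorine, or an amine nitrogen in place of the oxygen would keep the number this low is also unknown.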